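Shifting the hydroxymethyl group around the phenyl ring

The compounds below may be only part of what the source reports. "The series", "measured", "known", "first", "only" and "open" are said of these compounds alone.

Compound 1, `CCCC[S+]([O-])c1sc2nc(-c3nccs3)cc(-c3ccc(CN)cc3)c2c1N`: 11.5 nM
Compound 2, `CCCC[S+]([O-])c1sc2nc(-c3nccs3)cc(-c3ccc(CCO)cc3)c2c1N`: 2.9 nM
Compound 3, `CCCC[S+]([O-])c1sc2nc(-c3nccs3)cc(-c3ccc(CO)cc3)c2c1N`: 2.5 nM

In an assay for inhibition of 15-hydroxyprostaglandin dehydrogenase [NAD(+)] (Homo sapiens), read by fluorescence, with a stated time of 15 min, in the presence of a further agent that is not named here (a lower number here means a stronger inhibitor, a higher number a weaker inhibitor), compound 3 gives the lowest of the three numbers, though its gap to compound 2 is within the scatter, a 1.2-fold lower number from compound 2 to compound 3 (0.06 log units; within the scatter), while the gap to compound 1 is beyond it, a 4.6-fold lower number from compound 1 to compound 3 (0.66 log units; beyond the scatter). Compound 4, `CCCC[S+]([O-])c1sc2nc(-c3nccs3)cc(-c3cccc(CO)c3)c2c1N`, differs from compound 3 only in how the same atoms are joined: 3-(hydroxymethyl)phenyl in place of 4-(hydroxymethyl)phenyl on an aromatic carbon. Among the compounds with values here, none of the measured steps concerns such a shift; a 4.0-fold lower number from compound 1 to compound 2 (0.60 log units; beyond the scatter) and a 4.6-fold lower number from compound 1 to compound 3 (0.66 log units; beyond the scatter) exchange the group on the chain carbon and leave its place on the ring unchanged. The data therefore give no direct guide. A modest weakening is expected for compound 4, a 2.4-fold higher number from compound 3 to compound 4 (0.38 log units; beyond the scatter), with an estimate of 6 nM and a range from 2 nM to 20 nM.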

Compound 4, half-maximal inhibitory concentration: 4.3 nM
Estimate against measurement, compound 4: 1.4-fold (0.14 log units) above; low and high end bracket the measured number.
By their numbers in this assay, from the lowest: compounds 3, 2 and 4 (each within the scatter of the next); then compound 1.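

In this assay, shifting the group from 4-(hydroxymethyl)phenyl to 3-(hydroxymethyl)phenyl stays within the scatter (a 1.7-fold higher number from compound 3 to compound 4 (0.24 log units; within the scatter)), so the place of the hydroxymethyl on the ring makes no clear difference here. The step from the 2-hydroxyethyl group is also within the scatter (a 1.5-fold higher number from compound 2 to compound 4 (0.17 log units; within the scatter)), while the gain over the aminomethyl group remains beyond it (a 2.7-fold lower number from compound 1 to compound 4 (0.43 log units; beyond the scatter)). Nothing available here bears on this result. Still open, going by these compounds, is whether 3-(aminomethyl)phenyl or 3-(2-hydroxyethyl)phenyl would follow compound 4, and how a carboxylic acid on this ring would compare.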